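Chloro to Amino on the Fused Ring: Expected Growth Inhibition

A few compounds are considered here, and "the series" means these few. Any claim that something is new, unique, unknown or untested is made for them only; others in the source may bear on it.

Measured in a functional assay on HT-29 cells (Homo sapiens) for cytotoxicity, read by sulforhodamine B assay, with a stated time of 48 h; on this read-out lower numbers stand for stronger inhibition of growth and higher numbers for weaker inhibition of growth:
compound 1, `CCn1cc(-c2nc3ccccc3[nH]2)c(=O)c2cc(F)c(N3CCNCC3)cc21`, reaches only a limit of the assay: > 10000 nM
compound 2, `CCn1cc(-c2nc3ccc(Cl)cc3[nH]2)c(=O)c2cc(F)c(N3CCNCC3)cc21`, gives 1800 nM
compound 3, `CCn1cc(-c2nc3ccc([N+](=O)[O-])cc3s2)c(=O)c2cc(F)c(N3CCN(C)CC3)cc21`, reaches only a limit of the assay: > 10000 nM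

Compound 2 is the only one of the three that gives an actual number in this assay; the other two sit at a limit of the assay, (the limit of > 10000 nM in this assay, at which 2 of the 3 values shown sit). Among the measured compounds shown here, the one step measured in a single place is an at least 5.5-fold lower number from compound 1 to compound 2 (0.74 log units; beyond the scatter), where chloro replaces hydrogen on the aromatic carbon of the fused ring. Compound 3 carries a nitro group and a different core, and its values show only that it, too, reached the limit.

Compound 4, `CCn1cc(-c2nc3ccc(N)cc3[nH]2)c(=O)c2cc(F)c(N3CCNCC3)cc21`, differs from compound 2 in one place: amino in place of chloro on an aromatic carbon. For the measured compounds named here, the measured step from compound 1 to compound 2 shows that the group at this aromatic carbon changes the read-out beyond the scatter, but no measured compound carries amino there, so nothing shows which way amino moves it. With chloro gone, the expectation is a return part of the way toward the limit seen for compound 1, a step of a 3.3-fold higher number from compound 2 to compound 4 (0.52 log units; beyond the scatter). Compound 4 is therefore estimated at 6000 nM, with a range from 1500 nM to 20000 nM, and a real chance that only a limit is reported.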

Compound 4, concentration for 50% growth inhibition: > 10000 nM
Compound 4: only a limit was reported; the forecaster's own chance of this, stated with the estimate: 40%; middle value at least 1.6-fold (0.22 log units) from the limit.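

In this assay, this aromatic carbon now has a second change to compare with chloro, and amino does not keep what chloro gained: the result is an at least 5.5-fold higher number from compound 2 to compound 4 (0.74 log units; beyond the scatter). The earlier step showed only that chloro in place of hydrogen lowers the number, whereas this one shows that the lower number does not follow from having just any single-atom group at this carbon, and among the three compounds sharing this core, only the chloro compound gives an actual number. Amino and hydrogen cannot be ranked against each other, and the step between them cannot be read, because compound 1 and compound 4 both reach only a limit of the assay: the limit of > 10000 nM in this assay, at which 3 of the 4 values shown sit.

As far as these compounds go, how far the true value of compound 4 lies from that limit stays open, and with it the full size of the loss on replacing chloro with amino. Also open, from the compounds shown here alone, is whether another group on this carbon, such as bromo, methoxy or a carboxylic acid, would match chloro, give a lower number or return to the limit.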